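The source may hold more compounds than are shown below. What is called first, only, known or untested is meant among the compounds shown, and "the series" means these compounds.

Series notes. Compound 1 `CC1CCC(=O)N1CC#CCn1ccnc1` carries 1H-imidazol-1-yl on a saturated chain carbon bound to a triple-bonded carbon; compound 2 `CC1CCC(=O)N1CC#CCN(C)C` has dimethylamino at that place. In a functional assay on the whole organism for antagonist activity, with Mus musculus as the target (on this read-out lower numbers stand for an effect already at smaller amounts and higher numbers for an effect only at larger amounts of compound), compound 1 gives 1.1 mg/kg. Compound 2 reaches only a limit of this assay, > 100 mg/kg. The change dimethylamino in place of 1H-imidazol-1-yl on a saturated chain carbon bound to a triple-bonded carbon therefore made an at least 90-fold higher number from compound 1 to compound 2 (1.95 log units; beyond the scatter). Compound 3 `COC(=O)N(C)CC#CCn1ccnc1` keeps the 1H-imidazol-1-yl group on another core; the difference between the core of compound 3 and the core of compound 1 is not broken down here. In this assay compound 3 also gives only a limit, > 100 mg/kg. Compound 4 `COC(=O)N(C)CC#CCN(C)C` is compound 3 with the same change, (dimethylamino in place of 1H-imidazol-1-yl on a saturated chain carbon bound to a triple-bonded carbon), at the same place. The step expected from compound 3 to compound 4 in this assay is a step that the limit leaves unreadable from compound 3 to compound 4, and it remains a rough guess, because the limit of > 100 mg/kg in this assay, at which 2 of the 3 values shown sit, already holds compound 3 and leaves no measured direction to extend. The expected outcome for compound 4 in this assay is 300 mg/kg, most likely again reported as a limit rather than as a number.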

Compound 4, dose for half-maximal effect: > 30 mg/kg
Compound 4 ended at the assay's limit; the forecaster's own chance of this, stated with the estimate: 90%; the middle value lies beyond the limit too.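

Compound 3 and compound 4 both give only limits in this assay, and the step between them cannot be read. The compounds shown leave open whether dimethylamino in place of 1H-imidazol-1-yl has any effect on the core of compound 3 comparable to the one seen on the other core, an at least 90-fold higher number from compound 1 to compound 2 (1.95 log units; beyond the scatter).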